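Chloro Added to the Aromatic Ring of Compound 2

The source may report more compounds than this note shows. Statements on the series, on what has been measured and on what is new or still open speak of the compounds shown alone.

Compound 1 `CC1(C)[C@@H]2CC[C@@]1(CS(=O)(=O)N1CCN(c3ncc(C(F)(F)F)cc3Cl)CC1)C(=O)C2`: 398 nM
Compound 2 `CC1(C)[C@@H]2CC[C@@]1(CS(=O)(=O)N1CCN(c3ccc(C(F)(F)F)c(Cl)n3)CC1)C(=O)C2`: 251 nM

In a functional assay on CHO-K1 cells for antagonist activity at C-X-C chemokine receptor type 3 (Homo sapiens), read by FLIPR and calcium flux (on this read-out lower numbers stand for stronger inhibition and higher numbers for weaker inhibition), compound 2 holds the lower of the two numbers shown, though compound 1 lies within the scatter of it. Compound 3 `CC1(C)[C@@H]2CC[C@@]1(CS(=O)(=O)N1CCN(c3nc(Cl)c(C(F)(F)F)cc3Cl)CC1)C(=O)C2` differs from compound 2 in a single place: chloro in place of hydrogen on an aromatic carbon. No measured pair among these compounds shows such a change, so its size and direction are unknown here. The step from compound 2 to compound 3 is expected to be a 1.0-fold lower number from compound 2 to compound 3 (0.00 log units; within the scatter), not beyond the scatter either way. Compound 3 is accordingly estimated at 250 nM, with a range from 80 nM to 800 nM.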

Compound 3, half-maximal inhibitory concentration: 316 nM
Beside the measured number, compound 3's estimate is 1.3-fold (0.10 log units) below it, within the range that was stated.
By their numbers in this assay, from the lowest: compounds 2, 3 and 1 (each within the scatter of the next).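

In this assay, chloro in place of hydrogen on the aromatic carbon para to a chloro group and ortho to a large group gives a 1.3-fold higher number from compound 2 to compound 3 (0.10 log units; within the scatter), so this position accepts the atom without a step beyond the scatter. The same kind of replacement, read from the other side, gives a 1.3-fold lower number from compound 1 to compound 3 (0.10 log units; within the scatter), and this step also stays within the scatter. No measurement on hand offers a reason for either step. As far as these compounds go, whether a methoxy group, an amine or a nitrile on this carbon would also stay within the scatter remains open.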